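The source may report more compounds than this note shows. Statements on the series, on what has been measured and on what is new or still open speak of the compounds shown alone.

Measured compounds in an ADME assay on A549 cells (Homo sapiens) for cytotoxicity, read by resazurin assay, with a stated time of 48 h; a higher number here means that more compound is tolerated, a lower number that less compound is tolerated:
compound 1, `O=C(Nc1ccc(NCC2CC2)cc1Cl)c1cc(Cl)ccc1O`, 14400 nM
compound 2, `O=C(Nc1ccc(N(CC2CC2)CC2CC2)cc1Cl)c1cc(Cl)ccc1O`, 12800 nM
compound 3, `O=C(Nc1ccc(NCc2ccc(Br)cc2)cc1Cl)c1cc(Cl)ccc1O`, 40900 nM

Compound 3 gives the highest number of the three: the step of a 2.8-fold higher number from compound 1 to compound 3 (0.45 log units; beyond the scatter) and the step of a 3.2-fold higher number from compound 2 to compound 3 (0.50 log units; beyond the scatter) both lie beyond the scatter, whereas a 1.1-fold lower number from compound 1 to compound 2 (0.05 log units; within the scatter) does not. Compound 4, `O=C(Nc1ccc(NCc2ccc(Br)s2)cc1Cl)c1cc(Cl)ccc1O`, is not yet measured. It differs from compound 3 as follows: 5-bromothiophen-2-yl in place of 4-bromophenyl on a saturated chain carbon bound to a nitrogen on an aromatic ring. Among the compounds with values here, no measured step bears directly on this change; the measured steps exchange cyclopropyl for 4-bromophenyl or add a second cyclopropylmethyl, and the only ones beyond the scatter, a 2.8-fold higher number from compound 1 to compound 3 (0.45 log units; beyond the scatter) and a 3.2-fold higher number from compound 2 to compound 3 (0.50 log units; beyond the scatter), concern a change of a different kind. The exchange of one bromine-bearing aromatic ring for another is a smaller alteration than anything measured in this series, so in this assay no step beyond the scatter is expected; if the number moves at all, a slight drift back toward the level of compound 1 seems the more likely direction. The expected step is a 1.4-fold lower number from compound 3 to compound 4 (0.13 log units; within the scatter). For compound 4 the estimate is 30000 nM, with a range from 12000 nM to 70000 nM.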

Compound 4, half-maximal cytotoxic concentration: 20700 nM
For compound 4 the middle estimate is 1.4-fold (0.16 log units) above the measured one; the range from low to high includes it.
By their numbers in this assay, from the lowest: compounds 2, 1, 4 and 3 (each within the scatter of the next, the first and the last beyond it).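

Within this assay, 5-bromothiophen-2-yl in place of 4-bromophenyl on the saturated chain carbon gives a 2.0-fold lower number from compound 3 to compound 4 (0.30 log units; within the scatter) and so stays within the scatter: this place accepts a five-membered aromatic ring with a hetero atom as well as a six-membered aromatic ring of carbon only. Compound 4 also lies within the scatter of the cyclopropylmethyl compounds, with a 1.4-fold higher number from compound 1 to compound 4 (0.16 log units; within the scatter) and with a 1.6-fold higher number from compound 2 to compound 4 (0.21 log units; within the scatter) as the steps, so the separation of compound 3 from compound 1 and compound 2 is not shared by this second bromine-bearing aromatic group, and a bromine-bearing aromatic ring at this place does not by itself mark a separate level. Nothing at hand explains the pattern of these values.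

The compounds shown leave open whether the separation of compound 3 belongs to its bromine or to its ring, a question that a plain benzyl group or a 4-chlorobenzyl group at the same nitrogen would address. Also open, going by these compounds, is how a pyridine ring, or a longer chain between that nitrogen and the aromatic ring, would read in this assay.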